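The source may hold more compounds than are shown below. What is called first, only, known or untested is meant among the compounds shown, and "the series" means these compounds.

Three hydrazones built on a shared core have been examined in a functional assay on HeLa cells (Homo sapiens) for inhibition, read by sulforhodamine B assay, with a stated time of 48 h; a lower number here means a stronger inhibitor of growth, a higher number a weaker inhibitor of growth. Compound 1 `Cc1ccc(C(=O)N/N=C/C2=C(Cl)c3ccccc3CCC2)cc1` gives 300 nM. Compound 2 `O=C(N/N=C/C1=C(Cl)c2ccccc2CCC1)c1cccc(C(F)(F)F)c1` gives 16300 nM. Compound 3 `Cc1cc2c(cc1C)C(Cl)=C(/C=N/NC(=O)c1ccccc1)CCC2` reaches only the limit of the assay, reported as > 100000 nM. It thus stands at the limit of > 100000 nM in this assay, at which 1 of the 3 values shown sits, with no number of its own. Compound 4 `Cc1cc2c(cc1C)C(Cl)=C(/C=N/NC(=O)c1cccnc1)CCC2` differs from compound 3 in one place: pyridin-3-yl in place of phenyl on a carbonyl carbon. Among the measured compounds shown here, no measured pair shows this exchange, so its size cannot be read from the data. Since compound 3 offers only a limit, compound 4 is expected to stay weak in this assay, with an expected step of a number no higher from compound 3 to compound 4 (the limit leaves the size open). Compound 4 is estimated at 100000 nM, within 20000 nM to 300000 nM.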

Compound 4, concentration for 50% growth inhibition: 650 nM
Compound 4: middle estimate off by 150-fold (2.19 log units), on the high side, outside the stated range (below it).
By their numbers in this assay, from the lowest: compound 1; then compound 4; then compound 2. At a limit, above all of these: compound 3.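

In this assay, pyridin-3-yl in place of phenyl on a carbonyl carbon gives an at least 150-fold lower number from compound 3 to compound 4 (2.18 log units; beyond the scatter). Among the compounds shown here, this is the first exchange at this place that can be read, and it shows that this one ring change alone can carry the dimethyl-substituted series from a limit to a measured value. The step is only a minimum because compound 3 has a limit and no number of its own: the limit of > 100000 nM in this assay, at which 1 of the 4 values shown sits.

On these data alone, whether the same exchange acts alike on the core of compound 1 stays open. So does the outcome with a pyrimidine ring or an aminophenyl group at this place.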